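A Methoxy Added to Compound 2

The compounds below may be only part of what the source reports. "The series", "measured", "known", "first", "only" and "open" are said of these compounds alone.

The study compares three measured compounds and a fourth still to be tested. Compound 1 `COc1ccc(-c2nc(SCC(=O)c3sc(-c4ccccc4)nc3C)[nH]c(=O)c2C#N)cc1` gives 97.3% in a functional assay on U-87MG ATCC cells for antiproliferative activity against U-87 MG (Homo sapiens), read by MTT assay, with a stated time of 48 h, tested at 5 uM; on this read-out higher numbers stand for a weaker effect at the one concentration tested and lower numbers for a stronger effect. Compound 2 `COc1ccc(-c2nc(SCC(=O)c3sc(-c4ccccc4)nc3C)nc(N)c2C#N)cc1` gives 68.8% in this assay, and compound 3 `COc1ccc(-c2nc(C)c(C(=O)CSc3nc(-c4ccc(OC)cc4)c(C#N)c(=O)[nH]3)s2)cc1` gives 97%. Compound 2 stands lowest of the three, and both of its gaps to the other two lie beyond the scatter, so at the concentration tested it shows the strongest effect of the measured set.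

Compound 4 `COc1ccc(-c2nc(C)c(C(=O)CSc3nc(N)c(C#N)c(-c4ccc(OC)cc4)n3)s2)cc1` is compound 2 with one change: methoxy in place of hydrogen on an aromatic carbon. The same change has already been seen once in this series, and there the step was a number 0.3 percentage points lower from compound 1 to compound 3 (within the scatter), a step within the scatter. On that evidence, methoxy in place of hydrogen on an aromatic carbon has not moved the read-out in this assay, and the account expects no step beyond the scatter for compound 4 either. The expected step is therefore a number 0.8 percentage points lower from compound 2 to compound 4 (within the scatter). For compound 4 the estimate in this assay is 68%, with a range from 54% to 82%.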

Compound 4, a percentage reported as activity, at one concentration (the size of the read-out at that concentration, not a potency): 35.6%
Compound 4: the middle estimate sits 32.4 percentage points above what was measured, and the stated range ends above it.
By their numbers in this assay, from the lowest: compound 4; then compound 2; then compounds 3 and 1 (each within the scatter of the next).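

In this assay the change from phenyl to 4-methoxyphenyl proves able to move the read-out, with a number 33.2 percentage points lower from compound 2 to compound 4 (beyond the scatter), so the flat step seen earlier does not hold for this position in general. The outcome of the change depends on the core that carries it: the same change on two cores in this assay, a number 0.3 percentage points lower (within the scatter) from compound 1 to compound 3 and a number 33.2 percentage points lower (beyond the scatter) from compound 2 to compound 4, 32.9 percentage points apart, beyond the scatter of two such steps The position on the six-membered aromatic ring of carbon only, para to a large group, is therefore one where adding methoxy can matter a great deal on one core and leave the number in place on the other, and the two pairs of compounds give no single size for this change.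

The compounds shown carry only hydrogen or methoxy at this position, so it remains open whether fluorine, a hydroxyl group or an ethoxy group would follow the large step or the flat one on the core of compound 2. Among the compounds shown here, with only two pairs, each read at a single concentration, it also remains open which part of the difference between the two cores decides the size of the step, and how the step would look as a potency.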